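Ester-side variation in the dihydropyridine series

This account rests on a few compounds, and the source may have more. Where it says the series, first, only, none or still open, it means among the compounds named here.

Going by the values given here, compound 2 `COC(=O)C1=C(C)NC(C)=C(C(=O)OCCCCc2ccc(OC)cc2)C1c1cccc([N+](=O)[O-])c1` is the weaker of the two compounds measured in a functional assay on HEK293 cells for antagonist activity at Voltage-dependent L-type calcium channel subunit alpha-1D (Rattus norvegicus), read by FLIPR (a lower number here means a stronger inhibitor, a higher number a weaker inhibitor), where compound 2 gives 38 nM; compound 1 `C=CCOC(=O)C1=C(C)NC(C)=C(C(=O)OC)C1c1cccc([N+](=O)[O-])c1` gives 15 nM, and the only measured step, a 2.5-fold higher number from compound 1 to compound 2 (0.40 log units; beyond the scatter), bears on the same position. Compound 3 `COC(=O)C1=C(C)NC(C)=C(C(=O)OCc2ccc(-c3ccccc3)cc2)C1c1cccc([N+](=O)[O-])c1` carries 4-phenylphenyl in place of 3-(4-methoxyphenyl)propyl on a saturated chain carbon bound to an oxygen next to a carbonyl group. Among the compounds with values here, because the one comparable step is a 2.5-fold higher number from compound 1 to compound 2 (0.40 log units; beyond the scatter), exchanging the ester substituent is expected to shift this assay only modestly, so a small step of about a 1.3-fold higher number from compound 2 to compound 3 (0.12 log units; within the scatter) toward a higher number is expected. Compound 3 is therefore estimated at 50 nM, with a range from 15 nM to 160 nM.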

Compound 3, half-maximal inhibitory concentration: 74 nM
The estimate for compound 3 lay 1.5-fold (0.17 log units) below the measured number, within the range that was stated.
By their numbers in this assay, from the lowest: compound 1; then compounds 2 and 3 (each within the scatter of the next).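

In this assay, 4-phenylphenyl in place of 3-(4-methoxyphenyl)propyl gives a 1.9-fold higher number from compound 2 to compound 3 (0.29 log units; within the scatter), so these two aromatic ester groups are not separated at this position. Measured against the vinyl group of compound 1, the same 4-phenylphenyl group gives a 4.9-fold higher number from compound 1 to compound 3 (0.69 log units; beyond the scatter), so compound 2 and compound 3 both stand apart from compound 1. No available evidence accounts for these steps.

From the compounds shown here alone, whether a terminal amine or carboxylic acid on the ester chain would change the number remains open. So does the effect of a simple ethyl ester.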